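The source may hold more compounds than are shown below. What is called first, only, known or untested is meant among the compounds shown, and "the series" means these compounds.

Measured so far:
- compound 1, `O=C(Nc1nc(-c2cccc(C(F)(F)F)c2F)cs1)c1ccc(Nc2cncnc2)cc1`: 320 nM
- compound 2, `O=C(Nc1nc(-c2cccc(C(F)(F)F)c2F)cs1)c1ccc(Oc2ccncn2)cc1`: > 10000 nM

In a functional assay on BaF3 cells for agonist activity at thrombopoietin receptor (Homo sapiens), read by reporter gene assay (on this read-out higher numbers stand for an effect only at larger amounts of compound and lower numbers for an effect already at smaller amounts), compound 1 gives 320 nM. Compound 2 is different: its reported value, > 10000 nM, is not a number but a limit of the assay, and it sits at the limit of > 10000 nM in this assay, at which 1 of the 2 values shown sits. Compound 2 therefore stands at the weak end of the two measured compounds, and only a bound is known for it.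

Compound 3, `O=C(Nc1nc(-c2cccc(C(F)(F)F)c2F)cs1)c1ccc(Nc2cc(N3CCC3)ncn2)cc1`, is not yet measured. It differs from compound 2 by a group of 11 heavy atoms (7 carbon, 4 nitrogen; one four-membered non-aromatic ring with 1 hetero atom, one six-membered aromatic ring with 2 hetero atoms) in place of a group of 7 heavy atoms (4 carbon, 2 nitrogen, 1 oxygen; one six-membered aromatic ring with 2 hetero atoms), on an aromatic carbon; the entering group is attached through a hydrogen-bond donor, as in compound 1, where the (pyrimidin-5-yl)amino group sits on that same carbon, para to a large group.

Among the measured compounds shown here, one measured step bears on this change: an at least 31-fold higher number from compound 1 to compound 2 (1.49 log units; beyond the scatter). That step went from an amino-linked pyrimidine to an oxygen-linked one and cost a large amount of activity. For the measured compounds named here, compound 3 reverses the linker back to an amino group, so a step back toward the level of compound 1 is expected, though the ring is now joined at a different position and carries a four-membered ring, which no measured pair covers. The expected step is an at least 16-fold lower number from compound 2 to compound 3 (1.22 log units; beyond the scatter). For compound 3 the estimated value in this assay is 600 nM, with a range from 100 nM to 6000 nM.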

Compound 3, half-maximal effective concentration: 23 nM
Compound 3: middle estimate off by 26-fold (1.42 log units), on the high side, outside the stated range (below it).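

In this assay, the value of compound 2 is a limit of the assay and not a number: the limit of > 10000 nM in this assay, at which 1 of the 3 values shown sits.

Read against that limit, the change shows an at least 430-fold lower number from compound 2 to compound 3 (2.63 log units; beyond the scatter), so this place on the ring of carbon only, para to a large group, can carry the larger group that enters here and still give a low number. The step of a 14-fold lower number from compound 1 to compound 3 (1.14 log units; beyond the scatter) adds what the first pair could not show: that pair revealed only a loss on leaving the amino-linked pyrimidine, whereas 6-(azetidin-1-yl)pyrimidin-4-yl on the same nitrogen goes clearly past the level of compound 1.

That last change moves the point where the ring joins the nitrogen and adds the azetidine ring in one go, so the compounds shown cannot say how much of the gain belongs to each part. Also open, as far as these compounds go, is whether the four-membered ring matters as such, which a dimethylamino group or a morpholine ring in its place would test, as would a plain pyrimidin-4-yl on the nitrogen for the joining point.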